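The source may hold more compounds than are shown below. What is called first, only, known or untested is meant among the compounds shown, and "the series" means these compounds.

Measured so far in an ADME assay on HEp-2 cells (Homo sapiens) for cytotoxicity; a higher number here means that more compound is tolerated, a lower number that less compound is tolerated:
- compound 1 `CC(C)CCn1c(CN2C(=O)CSc3ccccc32)nc2ccccc21`: 6780 nM
- compound 2 `O=c1c(O)cc2ccccc2n1Cc1nc2ccccc2n1CCCCF`: 20200 nM

Compound 1, at 6780 nM, stands lowest of the two, and compound 2 gives the higher 20200 nM, a gap beyond the usual scatter. Compound 3 `O=C1CSc2ccccc2N1Cc1nc2ccccc2n1CCCCF` has not yet been measured. It carries 2-fluoroethyl in place of isopropyl on a saturated chain carbon, two bonds along the chain from an aromatic nitrogen; cut one bond further out, this reads isopentyl to 4-fluorobutyl. Going by the values given here, no measured step shows what this change does, so only a small upward move in this assay is expected, possibly within the scatter. The expected step is a 1.5-fold higher number from compound 1 to compound 3 (0.17 log units; within the scatter). For compound 3 the estimated value is 10000 nM, with an expected range from 4000 nM to 25000 nM.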

Compound 3, half-maximal cytotoxic concentration: > 96300 nM
Compound 3 gave a limit, no number (the forecaster's own chance of this, stated with the estimate: 15%); at least 9.6-fold (0.98 log units) between middle value and limit.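

In this assay, 2-fluoroethyl in place of isopropyl on a saturated chain carbon, two bonds along the chain from an aromatic nitrogen, gives an at least 14-fold higher number from compound 1 to compound 3 (1.15 log units; beyond the scatter) and so shows that this one change on the shared core can move the tolerated concentration by a large step. Compound 3 gives a limit and no number: the limit of > 96300 nM in this assay, at which 1 of the 3 values shown sits.

Going by these compounds, whether a plain butyl chain at this place would give the same rise stays open, leaving the share of the fluorine unsettled. On these data alone, whether isopentyl would lower the number on the core of compound 2 also stays open.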